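Removing the Amino Substituent from Compound 2

A few compounds are considered here, and "the series" means these few. Any claim that something is new, unique, unknown or untested is made for them only; others in the source may bear on it.

In a functional assay on MCF7 cells (Homo sapiens) for inhibition, read by CCK-8 assay, with a stated time of 4 days (on this read-out lower numbers stand for stronger inhibition and higher numbers for weaker inhibition), compound 1 (`COc1cc(C(=O)O)ccc1NC(=O)[C@@H]1N[C@@H](CC(C)(C)C)[C@](CNCc2ccncc2)(c2ccc(Cl)cc2F)[C@H]1c1cccc(Cl)c1F`) gives 520 nM and compound 2 (`COc1cc(C(=O)O)ccc1NC(=O)[C@@H]1N[C@@H](CC(C)(C)C)[C@](CNCc2ccc(O)cc2)(c2ccc(Cl)cc2F)[C@H]1c1cccc(Cl)c1F`) gives 830 nM, so compound 2 stands level with compound 1 within the scatter. For the measured compounds named here, the one measured step, a 1.6-fold higher number from compound 1 to compound 2 (0.20 log units; within the scatter), places 4-hydroxyphenyl in place of pyridin-4-yl. Compound 3 (`COc1cc(C(=O)O)ccc1NC(=O)[C@@H]1N[C@@H](CC(C)(C)C)[C@](C)(c2ccc(Cl)cc2F)[C@H]1c1cccc(Cl)c1F`) differs from compound 2 as follows: hydrogen in place of (4-hydroxybenzyl)amino on a saturated chain carbon bound to a saturated ring carbon. Going by the values given here, no measured step removes this whole group, so the evidence is weak and no shift beyond the scatter is predicted. The estimated change is a 1.2-fold lower number from compound 2 to compound 3 (0.07 log units; within the scatter). For compound 3 the expected value is 700 nM, with an estimated range from 170 nM to 2800 nM.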

Compound 3, half-maximal inhibitory concentration: 1870 nM
For compound 3 the middle estimate is 2.7-fold (0.43 log units) below the measured one, within the range that was stated.
By their numbers in this assay, from the lowest: compounds 1 and 2 (each within the scatter of the next); then compound 3.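

In this assay, removing the whole amino substituent carries a cost (a 2.3-fold higher number from compound 2 to compound 3 (0.35 log units; beyond the scatter)) and the same holds for the pyridine-bearing group (a 3.6-fold higher number from compound 1 to compound 3 (0.56 log units; beyond the scatter)), with both steps beyond the scatter, whereas the exchange of one ring for the other stayed within it. Among these three compounds, then, having the substituted amine on this saturated chain carbon matters more than which of the two rings it carries. Nothing shown gives a reason for this loss. From the compounds shown here alone, it remains open whether a primary amine alone on this carbon, or an ether oxygen in place of the amine nitrogen, would hold the numbers of compound 1 and compound 2, or whether the ring is needed as well.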